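The source may hold more compounds than are shown below. What is called first, only, known or untested is meant among the compounds shown, and "the series" means these compounds.

Three compounds share one core, and all were measured in a functional assay, read by spectrophotometry, with a stated time of 2 h; on this read-out higher numbers stand for weaker inhibition and lower numbers for stronger inhibition. Compound 1 `CC(C)[C@@H]1CC[C@@H](C)C[C@@]12N(C)C(=O)[C@@H]1[C@H]3C(=O)NC(=O)[C@H]3ON12` gives 1500 ug/mL. Compound 2 `CC(C)[C@@H]1CC[C@@H](C)C[C@@]12N(C)C(=O)[C@@H]1[C@H]3C(=O)N(C)C(=O)[C@H]3ON12`, which carries a methyl on the ring amide nitrogen, gives 1400 ug/mL. Compound 3 `Cc1cccc(N2C(=O)[C@H]3[C@H](ON4[C@@H]3C(=O)N(C)[C@@]43C[C@H](C)CC[C@H]3C(C)C)C2=O)c1`, which carries a 3-methylphenyl on that nitrogen, gives 2700 ug/mL. The step of a 1.8-fold higher number from compound 1 to compound 3 (0.26 log units; within the scatter) and the step of a 1.9-fold higher number from compound 2 to compound 3 (0.29 log units; within the scatter) show that hydrogen, methyl and 3-methylphenyl on that nitrogen all leave the number within the scatter, as does a 1.1-fold lower number from compound 1 to compound 2 (0.03 log units; within the scatter); compound 3 therefore sits alongside the other two rather than apart from them.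

Compound 4 `Cc1ccc(N2C(=O)[C@H]3[C@H](ON4[C@@H]3C(=O)N(C)[C@@]43C[C@H](C)CC[C@H]3C(C)C)C2=O)c(C)c1` is not yet measured. Its change from compound 3 is 2,4-dimethylphenyl in place of 3-methylphenyl on an amide-type nitrogen in a ring. Going by the values given here, the only steps that touch this nitrogen are the two just named, and both were within the scatter, so a further change at the same place is expected to give no step beyond the scatter in this assay. Compound 4 is therefore expected to give about 2700 ug/mL, with a range from 1300 ug/mL to 5500 ug/mL, which means an expected step of no change at the digits printed from compound 3 to compound 4 (within the scatter).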

Compound 4, half-maximal inhibitory concentration: 420 ug/mL
Beside the measured number, compound 4's estimate is 6.4-fold (0.81 log units) above it; measured number outside the range, below it.
By their numbers in this assay, from the lowest: compound 4; then compounds 2, 1 and 3 (each within the scatter of the next).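

In this assay, going by these compounds alone, this nitrogen proves more sensitive than the earlier compounds suggested: a 6.4-fold lower number from compound 3 to compound 4 (0.81 log units; beyond the scatter) is the first step at this place to lie beyond the scatter, although the leaving and entering groups are both six-membered aromatic rings of carbon only with no net charge. Compound 4 also separates from the compounds carrying methyl or hydrogen on that nitrogen, with a 3.3-fold lower number from compound 2 to compound 4 (0.52 log units; beyond the scatter) and a 3.6-fold lower number from compound 1 to compound 4 (0.55 log units; beyond the scatter), so having an aromatic ring there is not enough by itself, as compound 3 carries one and stays within the scatter of both. No measurement shown explains why this change lowers the number.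

From the compounds shown here alone, it remains open whether both methyl groups of 2,4-dimethylphenyl are needed. Also open, going by these compounds, is how a phenyl ring carrying chlorine or an amine in their place would read.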